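Replacing the aryl on the pyrazole nitrogen with isopropyl

The compounds below may be only part of what the source reports. "The series", "measured", "known", "first", "only" and "open" are said of these compounds alone.

Of the compounds shown here, three on a shared core have been tested in an ADME assay on Huh-7 cells (Homo sapiens) for cytotoxicity; a higher number here means that more compound is tolerated, a lower number that less compound is tolerated. Compound 1 `Cc1ccccc1-c1nn(-c2ccc(Cl)cc2)cc1CNCCN1CCN(C)CC1` gives 17000 nM. Compound 2 `Cc1ccccc1-c1nn(-c2ccccc2Cl)cc1CNCCN1CCN(C)CC1` gives > 20000 nM, which is a limit of the assay and not a number. Compound 3 `COc1ccc(-n2cc(CNCCN3CCN(C)CC3)c(-c3ccccc3C)n2)cc1` likewise gives > 20000 nM, again a limit rather than a number. The measured steps are modest: an at least 1.1-fold higher number from compound 1 to compound 2 (0.07 log units; that floor lies within the scatter) and an at least 1.1-fold higher number from compound 1 to compound 3 (0.07 log units; that floor lies within the scatter), while a step that the two limits leave unreadable from compound 2 to compound 3 since both values sit at the limit of > 20000 nM in this assay, at which 2 of the 3 values shown sit.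

Compound 4 `Cc1ccccc1-c1nn(C(C)C)cc1CNCCN1CCN(C)CC1` has not been measured; it differs from compound 3 by isopropyl in place of 4-methoxyphenyl on an aromatic nitrogen. Within the data shown here, no measured step exchanges an aromatic group for an alkyl group on that nitrogen, so none bears on it directly; the two exchanges of the group on that nitrogen already seen stayed within the scatter or at the limit. On that basis compound 4 is expected to show no step beyond the scatter, with a number no higher from compound 3 to compound 4 (the limit leaves the size open) as the estimated change. Compound 4 is therefore estimated at 20000 nM, between 10000 nM and 40000 nM, with a fair chance of another limit.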

Compound 4, half-maximal cytotoxic concentration: > 20000 nM
Compound 4 was reported as a limit (the forecaster's own chance of this, stated with the estimate: 60%); the middle value sits exactly at the limit.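

Among these compounds, with compound 4, a group with no ring stands on the aromatic nitrogen for the first time, and in this assay the result stays at the same limit as the aryl-bearing compound 2 and compound 3. Among the compounds shown here, the one readable step is an at least 1.1-fold higher number from compound 1 to compound 4 (0.07 log units; that floor lies within the scatter), while the steps to compound 4 from compound 2 and from compound 3 cannot be read. An aromatic ring on this nitrogen is therefore not required for a result at the limit, and the series gives no separation between aryl and isopropyl here: the limit of > 20000 nM in this assay, at which 3 of the 4 values shown sit.

As far as these compounds go, how far compound 2, compound 3 and compound 4 actually lie from one another remains unknown. From the compounds shown here alone, it also remains open whether an amine, a carboxylic acid or a longer alkyl chain on that nitrogen would give a readable number.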